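Methoxy on a Fused Aromatic Ring in a Cytotoxicity Series

The source may report more compounds than this note shows. Statements on the series, on what has been measured and on what is new or still open speak of the compounds shown alone.

Measured compounds:
compound 1 `CCOC(=O)c1c(-c2ccccc2)oc2ccc(OCCCN3C(=O)C(=O)c4ccccc43)cc12`, 256000 nM
compound 2 `CCOC(=O)c1c(-c2ccccc2)oc2ccc(OCCCN3C(=O)C(=O)c4cc(OC)ccc43)cc12`, 512000 nM
compound 3 `CCOC(=O)c1c(-c2ccccc2)oc2ccc(OCCCN3C(=O)/C(=N/O)c4ccccc43)cc12`, 512000 nM

In an ADME assay on CHO cells (Cricetulus griseus) for cytotoxicity, read by MTT assay, with a stated time of 72 h (a lower number here means that less compound is tolerated, a higher number that more compound is tolerated), compound 1 gives 256000 nM. Compound 2 differs from it by methoxy in place of hydrogen on an aromatic carbon, and the step is a 2.0-fold higher number from compound 1 to compound 2 (0.30 log units; within the scatter). Compound 3 carries a different core, (a group of 12 heavy atoms (8 carbon, 2 nitrogen, 2 oxygen; one five-membered non-aromatic ring with 1 hetero atom, one six-membered aromatic ring of carbon only) in place of a group of 11 heavy atoms (8 carbon, 1 nitrogen, 2 oxygen; one five-membered non-aromatic ring with 1 hetero atom, one six-membered aromatic ring of carbon only), on a saturated chain carbon, three bonds along the chain from an oxygen on an aromatic ring), and the step is a 2.0-fold higher number from compound 1 to compound 3 (0.30 log units; within the scatter); compound 3 and compound 2 stand level at the digits shown. Compound 4 `CCOC(=O)c1c(-c2ccccc2)oc2ccc(OCCCN3C(=O)/C(=N/O)c4cc(OC)ccc43)cc12` has not been measured in this assay. It differs from compound 3 by methoxy in place of hydrogen on an aromatic carbon, the same change as that from compound 1 to compound 2. Because the earlier step was a 2.0-fold higher number from compound 1 to compound 2 (0.30 log units; within the scatter), the step from compound 3 to compound 4 is expected to be a 1.2-fold higher number from compound 3 to compound 4 (0.07 log units; within the scatter). Compound 4 is therefore estimated at 600000 nM, between 300000 nM and 1200000 nM.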

Compound 4, half-maximal cytotoxic concentration: 512000 nM
Compound 4: middle estimate off by 1.2-fold (0.07 log units), on the high side, and the stated range covers the measured number.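

Measured in this assay methoxy in place of hydrogen on an aromatic carbon shows no change at the digits printed from compound 3 to compound 4 (within the scatter) on the core of compound 3. Set beside the earlier step on the core of compound 1, the two results do not differ by more than the scatter: the same change on two cores in this assay, a 2.0-fold higher number (0.30 log units; within the scatter) from compound 1 to compound 2 and no change at the digits printed (within the scatter) from compound 3 to compound 4, 2.0-fold (0.30 log units) apart, within the scatter of two such steps. The change therefore carries across these two cores without a detectable difference, but with neither step beyond the scatter, this does not show that methoxy moves the number on either core or that the result would hold on any other core.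

The compounds shown leave open whether an amine or a carboxylic acid on the same aromatic carbon would behave alike on both cores. They also leave open what a longer chain would do.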